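From azido to benzylamino on a sulfonyl sulfur

The compounds below may be only part of what the source reports. "The series", "measured", "known", "first", "only" and "open" are said of these compounds alone.

In a functional assay with Rattus norvegicus as the target (a lower number here means that less compound is needed, a higher number that more compound is needed for the effect), compound 1 `CC1(C)C=C(n2ccccc2=O)c2cc(S(=O)(=O)N=[N+]=[N-])ccc2O1` gives 204 nM. Compound 2 `CNS(=O)(=O)c1ccc2c(c1)C(n1ccccc1=O)=CC(C)(C)O2` gives 138 nM, and compound 3 `CC(C)NS(=O)(=O)c1ccc2c(c1)C(n1ccccc1=O)=CC(C)(C)O2` gives 1950 nM. Compound 1 thus sits with compound 2 at the low end of these three numbers, well apart from compound 3.

The unmeasured compound 4 `CC1(C)C=C(n2ccccc2=O)c2cc(S(=O)(=O)NCc3ccccc3)ccc2O1` carries benzylamino in place of azido on a sulfonyl sulfur. Two measured changes at the same place bear on it. Methylamino in place of azido gave a 1.5-fold lower number from compound 1 to compound 2 (0.17 log units; within the scatter), while isopropylamino in place of azido gave a 9.6-fold higher number from compound 1 to compound 3 (0.98 log units; beyond the scatter). Isopropyl in place of methyl on the sulfonamide nitrogen gave a 14-fold higher number from compound 2 to compound 3 (1.15 log units; beyond the scatter). Benzylamino is a larger group than methylamino, as isopropylamino is, so compound 3 is taken as the nearer guide. Among the measured compounds shown here, compound 2 shows that not every such replacement moves the number, and no compound with a benzyl group has been measured yet. A modest step towards a higher number in this assay is therefore expected, though a smaller one remains possible. The estimated step is a 5.9-fold higher number from compound 1 to compound 4 (0.77 log units; beyond the scatter). Compound 4 is expected at 1200 nM, with an estimated range from 250 nM to 6000 nM.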

Compound 4, half-maximal effective concentration: 1320 nM
Compound 4: middle estimate off by 1.1-fold (0.04 log units), on the low side; measured number inside the range.
By their numbers in this assay, from the lowest: compounds 2 and 1 (each within the scatter of the next); then compounds 4 and 3 (each within the scatter of the next).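

In this assay, benzylamino in place of azido gives a 6.5-fold higher number from compound 1 to compound 4 (0.81 log units; beyond the scatter), so a second, quite different group on the sulfonyl sulfur lands on the high side with isopropylamino. Benzyl in place of isopropyl on the sulfonamide nitrogen gives a 1.5-fold lower number from compound 3 to compound 4 (0.17 log units; within the scatter), which leaves these two compounds within the scatter of each other, so an aromatic ring on this nitrogen offers no return towards the low numbers. Phenyl in place of hydrogen on the chain carbon bound to the sulfonamide nitrogen gives a 9.6-fold higher number from compound 2 to compound 4 (0.98 log units; beyond the scatter), which leaves compound 2 as the only one of the three sulfonamides shown that stays within the scatter of compound 1, and nothing shown accounts for this.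

The compounds shown leave open where the rise sets in on going up from methylamino, a question that ethylamino or a plain amino group on the sulfur could address. They also leave open whether a second substituent on the nitrogen, as in dimethylamino, or a longer chain such as phenethylamino, would fall with compound 2 or with compound 3.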